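The source may hold more compounds than are shown below. What is called first, only, known or untested is meant among the compounds shown, and "the series" means these compounds.

Measured so far:
- compound 1 `CCCn1c(SCc2cc([N+](=O)[O-])ccc2OC)nc2cc(NC(=O)NC(C)(C)C)ccc21`: 18 nM
- compound 2 `COc1ccc([N+](=O)[O-])cc1CSc1nc2cc(NC(=O)NC(C)(C)C)ccc2n1Cc1ccccc1`: 28 nM

Both compounds were tested in an assay on isolated protein for inhibition of Gonadotropin-releasing hormone receptor (Homo sapiens); a higher number here means a weaker inhibitor, a lower number a stronger inhibitor. Compound 1 gives the lowest of the two numbers, and its nearest neighbour, compound 2, gives 28 nM, so the two values cannot be told apart. Among the measured compounds shown here, the one measured step, a 1.6-fold higher number from compound 1 to compound 2 (0.19 log units; within the scatter), changes only the group on the saturated chain carbon bound to the aromatic nitrogen and stays within the scatter.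

Compound 3 `CCCn1c(SCc2cc([N+](=O)[O-])ccc2OC)nc2cc(NC(=O)NC(C)(C)C)cc(C(=O)OC)c21` has not been measured. It differs from compound 1 in a single place: methoxycarbonyl in place of hydrogen on an aromatic carbon. For the measured compounds named here, no measured step touches that aromatic carbon, so the change has no direct precedent here; the only step available, from compound 1 to compound 2, concerns another part of the shared core and offers no guidance for this position. The expectation is therefore uncertain, with a broad range. The expected step is a 1.7-fold higher number from compound 1 to compound 3 (0.22 log units; within the scatter). For compound 3 the estimate in this assay is 30 nM, with a range from 8 nM to 120 nM.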

Compound 3, half-maximal inhibitory concentration: 37 nM
Compound 3: the middle estimate sits 1.2-fold (0.09 log units) below what was measured; the range from low to high includes it.
By their numbers in this assay, from the lowest: compounds 1, 2 and 3 (each within the scatter of the next, the first and the last beyond it).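

Placing methoxycarbonyl on this aromatic carbon, ortho to a fused ring, gives a 2.1-fold higher number from compound 1 to compound 3 (0.31 log units; beyond the scatter) in this assay and is the only step shown that lies beyond the scatter, though it is modest. The earlier pair varied only the group on the aromatic nitrogen, whereas this result shows that the aromatic carbon accepts a group of four heavy atoms with only a small loss of inhibition. No measured evidence explains this shift.

A single group cannot show how other groups would behave here: a carboxylic acid, an amine or a plain methyl on the same aromatic carbon could give quite different numbers. From the compounds shown here alone, whether methoxycarbonyl would produce a similar step on compound 2 also remains open.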